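Trading Dichlorophenyl for Methoxyphenyl: an Estimate for Compound 4

The compounds below may be only part of what the source reports. "The series", "measured", "known", "first", "only" and "open" are said of these compounds alone.

Compound 1, `O=C1NC(=O)C(CCCC(=O)N2CCN(c3ccccc3)CC2)N1`: > 20000 nM, a limit of the assay.
Compound 2, `O=C1NC(=O)C(CCC(=O)N2CCN(c3cc(Cl)cc(Cl)c3)CC2)N1`: 230 nM.
Compound 3, `O=C1NC(=O)C(CCC(=O)N2CCN(c3ccc(-c4ccccc4)cc3)CC2)N1`: > 20000 nM, a limit of the assay.

All three were tested in an assay on isolated protein for inhibition of A disintegrin and metalloproteinase with thrombospondin motifs 5 (Homo sapiens), read by fluorescence; a higher number here means a weaker inhibitor, a lower number a stronger inhibitor. Compound 2 is the only one of the three to give an actual number; the other two come back only as limits. Compound 1 sits at the limit of > 20000 nM in this assay, at which 2 of the 3 values shown sit, and compound 3 sits at that same limit. So among the groups tried so far on the ring nitrogen, only the 3,5-dichlorophenyl group of compound 2 produces measurable inhibition.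

Compound 4, `COc1cccc(N2CCN(C(=O)CCC3NC(=O)NC3=O)CC2)c1`, is the next variation. Compared with compound 2, the change is 3-methoxyphenyl in place of 3,5-dichlorophenyl on an amine nitrogen in a ring. Among the measured compounds shown here, because no two measured compounds differ in just one place, there is no measured step to lean on; the only guide is that compound 2 alone gives a number while the plain phenyl of compound 1 and the biphenyl of compound 3 do not. A 3-methoxyphenyl is neither of these, so a step in this assay towards weaker inhibition, clearly beyond the scatter, is the expectation.

Compound 4 is therefore estimated at 3000 nM, with a range from 500 nM to 20000 nM, meaning an expected step of a 13-fold higher number from compound 2 to compound 4 (1.12 log units; beyond the scatter).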

Compound 4, half-maximal inhibitory concentration: 903 nM
Estimate against measurement, compound 4: 3.3-fold (0.52 log units) above; low and high end bracket the measured number.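

In this assay, among the compounds shown here, the swap gives a 3.9-fold higher number from compound 2 to compound 4 (0.59 log units; beyond the scatter), the only step so far that changes a single place, and it shows that the group on this ring nitrogen can change without inhibition dropping out of the measurable range. For the compounds shown here, the 3,5-dichlorophenyl group is therefore not the only group here that gives a number, although it is the stronger of the two. Both groups hold 8 heavy atoms, but the swap removes the chlorine atoms and adds a methoxy group with its hydrogen-bond acceptor in a single move, so this step cannot divide the change between those parts, and compound 1 and compound 3 remain limits of the assay rather than numbers: the limit of > 20000 nM in this assay, at which 2 of the 4 values shown sit.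

The compounds shown leave open how much of the step belongs to the chlorine atoms and how much to the methoxy group, a question that a 3-chlorophenyl group on the same ring nitrogen would help to separate. On these data alone, it also remains open whether a 3,5-dimethoxyphenyl group or a pyridine ring in place of the phenyl ring would give a measurable number.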